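A few compounds are considered here, and "the series" means these few. Any claim that something is new, unique, unknown or untested is made for them only; others in the source may bear on it.

Measured compounds:
compound 1 `CC1(C)C=C(n2ccccc2=O)c2cc(S(=O)(=O)NCCO)ccc2O1` — 87.9%
compound 2 `CC(C)NS(=O)(=O)c1ccc2c(c1)C(n1ccccc1=O)=CC(C)(C)O2` — 94.8%

Within the data shown here, in a functional assay on the whole organism (trachea) with Rattus norvegicus as the target (on this read-out lower numbers stand for smaller maximal responses and higher numbers for larger maximal responses), compound 2 gives 94.8%, the higher of the two numbers measured so far. Its nearest neighbour is compound 1, which gives 87.9%; the step of a number 6.9 percentage points higher from compound 1 to compound 2 (within the scatter) lies within the scatter, so the two cannot be ordered.

Compound 3 `CC1(C)C=C(n2ccccc2=O)c2cc(S(=O)(=O)Nc3ccc(C#N)cc3)ccc2O1` has not yet been measured. It differs from compound 2 in one place: 4-cyanophenyl in place of isopropyl on a sulfonamide nitrogen. Among the measured compounds shown here, the one measured step, a number 6.9 percentage points higher from compound 1 to compound 2 (within the scatter), touches the same sulfonamide nitrogen and did not move the maximal response beyond the scatter. That step exchanged one small chain for another; the present change brings in a six-membered aromatic ring and a nitrile, so it is a larger structural move than any step measured so far, and the two compounds give no guide to a change of this kind. Given that the only step at this position was flat, no step beyond the scatter is expected, while the wider range reflects the lack of a comparable precedent.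

For compound 3 the expected value is 90% (range 70% to 105%), an estimated step of a number 4.8 percentage points lower from compound 2 to compound 3 (within the scatter).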

Compound 3, largest response reached (Emax), in percent of the reference or control that the assay uses: 90.8%
For compound 3 the middle estimate is 0.8 percentage points below the measured one, within the range that was stated.
By their numbers in this assay, from the lowest: compounds 1, 3 and 2 (each within the scatter of the next).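

In this assay the sulfonamide nitrogen now carries a much larger group without a step beyond the scatter: 4-cyanophenyl, with its six-membered aromatic ring and nitrile, replaces isopropyl in the step of a number 4 percentage points lower from compound 2 to compound 3 (within the scatter) and the maximal response cannot be told apart. Against 2-hydroxyethyl the picture is the same, with a number 2.9 percentage points higher from compound 1 to compound 3 (within the scatter) as the step, so all three substituents, two open chains and one aromatic ring, lie within the scatter of one another on this read-out and none of the three compounds can be placed above another. No measurement is available that would explain this flat response.

As far as these compounds go, whether the flat response extends to groups of another kind on this nitrogen remains open, for example a chain ending in an amine, a chain ending in a carboxylic acid, or a longer alkyl chain. A plain phenyl group would show whether the aromatic ring and the nitrile contribute separately, and since only the maximal response is given here, any differences among these compounds in other read-outs remain unknown.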